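A few compounds are considered here, and "the series" means these few. Any claim that something is new, unique, unknown or untested is made for them only; others in the source may bear on it.

Measured compounds:
compound 1, `Nc1cc(N)c2nc(-c3ccccc3)c(NCc3ccc(Cl)c(Cl)c3)nc2c1`, gives < 100000 nM in this cell assay, a limit rather than a number.
compound 2, `COc1cc(CNc2nc3cc(N)cc(N)c3nc2-c2ccccc2)cc(OC)c1OC`, gives 31600 nM.
compound 3, `CCOC(=O)[C@H](CCC(=O)O)NC(=O)c1ccc(Oc2nc3cc(N)cc(N)c3nc2-c2ccccc2)cc1`, gives 31600 nM.

The read-out is a functional assay on CAKI-1 cells (Homo sapiens) for inhibition, read by sulforhodamine B assay, with a stated time of 48 h; a higher number here means that more compound is tolerated, a lower number that less compound is tolerated. For compound 1 only a limit is reported (the limit of < 100000 nM in this assay, at which 1 of the 3 values shown sits), so its place among the numbers shown cannot be fixed: the two compounds with a number, compound 2 and compound 3, sit at the same value, and compound 1 is known only to lie somewhere under its limit. For the measured compounds named here, no step between two measured compounds is recorded, so nothing measured tells how a change on the benzyl group moves the read-out.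

The unmeasured compound 4, `Nc1cc(N)c2nc(-c3ccccc3)c(NCc3ccc(F)cc3)nc2c1`, differs from compound 1 in one place: 4-fluorophenyl in place of 3,4-dichlorophenyl on a saturated chain carbon bound to a nitrogen on an aromatic ring. The shared core and the aminomethyl linker are untouched. Since compound 1 itself has no number, the expectation for compound 4 rests on the level at which compound 2 and compound 3 sit, and on the modest nature of the change. The step from compound 1 to compound 4 is expected to be small, with no direction beyond the scatter, as a step that the limit leaves unreadable from compound 1 to compound 4. Compound 4 is expected to give about 30000 nM in this assay, with a range from 8000 nM to 100000 nM.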

Compound 4, concentration lethal to 50% of the cells: 89100 nM
Beside the measured number, compound 4's estimate is 3.0-fold (0.47 log units) below it; the measured number falls inside the stated range.
By their numbers in this assay, from the lowest: compounds 2 and 3 (each within the scatter of the next); then compound 4.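

The step from compound 1 to compound 4 cannot be read, because compound 1 carries only a limit and not a number: the limit of < 100000 nM in this assay, at which 1 of the 4 values shown sits. The compounds shown leave open how the change from 3,4-dichlorobenzyl to 4-fluorobenzyl, or any other change on the benzyl group, moves the read-out in this assay.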